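A few compounds are considered here, and "the series" means these few. Any claim that something is new, unique, unknown or untested is made for them only; others in the source may bear on it.

Measured compounds:
compound 1, `COc1ccc(-n2nncc2CN2C(=O)C3(C(C#N)=C(N)Oc4c3c3nc5ccccc5nc3c3ccccc43)c3ccccc32)cc1` — in a functional assay on MCF7 cells (Homo sapiens) for antiproliferative activity, read by MTT assay, with a stated time of 48 h (on this read-out higher numbers stand for weaker inhibition and lower numbers for stronger inhibition), compound 1 gives > 50000 nM
compound 2, `COc1ccccc1-n1nncc1CN1C(=O)C2(C(C#N)=C(N)Oc3c2c2nc4ccccc4nc2c2ccccc32)c2ccccc21` — compound 2 gives > 50000 nM
compound 3, `COc1ccc(-n2nncc2CN2C(=O)C3(C(C#N)=C(N)Oc4c(N)cc5nc6ccccc6nc5c43)c3ccccc32)cc1` — compound 3 gives > 50000 nM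

Each of these three values is a limit of the assay, not a number. The change from compound 1 to compound 2 is 2-methoxyphenyl in place of 4-methoxyphenyl on an aromatic nitrogen; the step it made is a step that the two limits leave unreadable from compound 1 to compound 2. Among the measured compounds shown here, all three values sit at the limit of > 50000 nM in this assay, at which 3 of the 3 values shown sit, so no step among the measured compounds can be read. The difference between the core of compound 1 and the core of compound 3 is not broken down here.

Compound 4, `COc1ccccc1-n1nncc1CN1C(=O)C2(C(C#N)=C(N)Oc3c(N)cc4nc5ccccc5nc4c32)c2ccccc21`, has not been measured. It differs from compound 3 by 2-methoxyphenyl in place of 4-methoxyphenyl on an aromatic nitrogen, the same change as between compound 1 and compound 2, at the same place. The step expected in this assay is a step that the limit leaves unreadable from compound 3 to compound 4, resting on compound 1 and compound 2 both sitting at the limit of > 50000 nM in this assay, at which 3 of the 3 values shown sit. Compound 4 is expected to give about 80000 nM, most likely reported again only as a limit.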

Compound 4, half-maximal inhibitory concentration: 28900 nM
Estimate against measurement, compound 4: 2.8-fold (0.44 log units) above; measured number below the stated range.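

In this assay, 2-methoxyphenyl in place of 4-methoxyphenyl on an aromatic nitrogen gives an at least 1.7-fold lower number from compound 3 to compound 4 (0.23 log units; that floor lies within the scatter). As far as these compounds go, on the core of compound 3, the change therefore goes with a measured number, but this floor does not establish a real gain and the size of the step stays unknown. Nothing shows that the change carries from one core to the other, since the step on the core of compound 1 and the remaining steps cannot be read: the limit of > 50000 nM in this assay, at which 3 of the 4 values shown sit.

The compounds shown leave open whether the result on the core of compound 3 would hold up with both partners measured as numbers. They also leave open how a carboxylic acid or an ethoxy group on that phenyl ring would read.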